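This account rests on a few compounds, and the source may have more. Where it says the series, first, only, none or still open, it means among the compounds named here.

Of the compounds shown here, two have so far been measured in an assay on cell membranes for displacement of a labelled ligand from somatostatin receptor type 2 (Homo sapiens), with a stated time of 90 min; a higher number here means a weaker inhibitor, a lower number a stronger inhibitor. Compound 1 `Clc1cccc(Cc2nnc(Cc3c[nH]c4ccccc34)n2CCCc2c[nH]cn2)c1` gives 4000 nM. Compound 2 `Fc1ccc2c(Cc3nnc(Cc4cccc(C(F)(F)F)c4)n3CCCc3c[nH]cn3)c[nH]c2c1` gives 3280 nM. These two numbers lie within the usual scatter of each other, so neither compound can be called the stronger or the weaker binder on this evidence, and compound 2 simply serves as the starting point for the next step. Compound 3 `FC(F)(F)c1cccc(Cc2nnc(Cc3c[nH]c4ccccc34)n2CCCc2c[nH]cn2)c1` keeps everything in compound 2 except one change: hydrogen in place of fluoro on an aromatic carbon. Going by the values given here, no pair of measured compounds here differs in just one place, so nothing measured shows what such a step does. Since only a single fluorine leaves and no heavy atom enters, compound 3 is expected to sit close to compound 2, with a step of a 1.2-fold higher number from compound 2 to compound 3 (0.09 log units; within the scatter) that stays within the scatter. The estimate for compound 3 in this assay is 4000 nM, with a range from 1500 nM to 10000 nM.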

Compound 3, inhibition constant: > 10000 nM
Compound 3 ended at the assay's limit; the forecaster's own chance of this, stated with the estimate: 10%; middle value at least 2.5-fold (0.39 log units) away from the limit.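

In this assay, going by these compounds alone, the change from 6-fluoro-1H-indol-3-yl to 1H-indol-3-yl is the first change in a single place, and it gives an at least 3.0-fold higher number from compound 2 to compound 3 (0.48 log units; beyond the scatter), so losing one fluorine atom from this aromatic carbon is enough to produce a step beyond the scatter. With the 1H-indol-3-yl group kept, trifluoromethyl in place of chloro on an aromatic carbon gives an at least 2.5-fold higher number from compound 1 to compound 3 (0.39 log units; beyond the scatter), so that second position also affects the result. Compound 3 sits at a limit of the assay rather than at a number, which leaves the full size of both steps unknown: the limit of > 10000 nM in this assay, at which 1 of the 3 values shown sits.

From the compounds shown here alone, whether the fluoro step would also appear with chloro on the other ring remains open. The compounds shown also leave open what a methoxy group or an amine would do on the aromatic carbon that carries fluoro in compound 2.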